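Swapping a nitrophenyl ether for a benzyl ether

This account rests on a few compounds, and the source may have more. Where it says the series, first, only, none or still open, it means among the compounds named here.

Measured so far in an ADME assay on HEK-293T cells (Homo sapiens) for cytotoxicity, read by CCK-8 assay, with a stated time of 48 h; on this read-out lower numbers stand for stronger inhibition and higher numbers for weaker inhibition:
compound 1, `O=S(=O)(NCCNC(=S)Nc1cccc(Cl)c1)c1ccc(-c2ccccc2OCc2ccccc2)s1`: 10200 nM
compound 2, `Cc1cc(C)cc(NC(=O)NCCNS(=O)(=O)c2ccc(-c3ccccc3OCc3ccccc3)s2)c1`: > 20000 nM
compound 3, `COc1ccc(NC(=O)NCCNS(=O)(=O)c2ccc(-c3ccccc3Oc3ccc([N+](=O)[O-])cc3)s2)cc1`: > 20000 nM

Compound 3, with its 4-nitrophenoxy group, gives only a limit in this assay, > 20000 nM, not a number. The same holds for compound 2, whose value in this assay is also a limit, > 20000 nM; these two sit at the limit of > 20000 nM in this assay, at which 2 of the 3 values shown sit. For the measured compounds named here, compound 1 is the only one with a measured number, 10200 nM.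

Compound 4, `COc1ccc(NC(=O)NCCNS(=O)(=O)c2ccc(-c3ccccc3OCc3ccccc3)s2)cc1`, differs from compound 3 by benzyl in place of 4-nitrophenyl on an oxygen on an aromatic ring, that is, 4-nitrophenoxy to benzyloxy. Going by the values given here, no measured step covers this change. The only step shown, an at least 1.9-fold higher number from compound 1 to compound 2 (0.29 log units; that floor lies within the scatter), concerns the group on the amine nitrogen and lies within the scatter; it is not the change at hand. Compounds 1 and 2 both carry the benzyloxy group of compound 4 and sit near or at the limit, so no step beyond the scatter is expected. Compound 4 is therefore estimated at 20000 nM, between 9000 nM and 45000 nM. Compound 4 is thus expected at a number no higher from compound 3 to compound 4 (the limit leaves the size open), most likely again reported as a limit.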

Compound 4, half-maximal inhibitory concentration: > 50000 nM
Compound 4 gave a limit, no number; the forecaster's own chance of this, stated with the estimate: 60%; middle value at least 2.5-fold (0.39 log units) away from the limit.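

In this assay compound 4 gives > 50000 nM, which is a limit and not a number. For the compounds shown here, with the benzyloxy group held in place, the change of group on the amine nitrogen gives an at least 4.9-fold higher number from compound 1 to compound 4 (0.69 log units; beyond the scatter), the first step at this position that clears the usual scatter, whereas the earlier step of an at least 1.9-fold higher number from compound 1 to compound 2 (0.29 log units; that floor lies within the scatter) did not. The swap of 4-nitrophenoxy for benzyloxy itself cannot be sized, and neither can the change from compound 2 to compound 4, as both ends of each pair are limits: the limit of > 50000 nM in this assay, at which 1 of the 4 values shown sits.

The compounds shown therefore leave open whether the group on the oxygen matters at all in this assay. Also open, as far as these compounds go, is what a plain methyl or a chain ending in an amine on that oxygen would give.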